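Halogen Swap on a Benzyl Sulfide and Cytotoxicity

The source may report more compounds than this note shows. Statements on the series, on what has been measured and on what is new or still open speak of the compounds shown alone.

Compound 1 `Cn1cc(SCc2nnc(SCc3cc(C(F)(F)F)ccc3Cl)n2-c2c(Cl)cccc2Cl)c2ccccc21` — in a toxicity assay on HEK-293T cells (Homo sapiens) for cytotoxicity, read by CCK-8 assay, with a stated time of 48 h (on this read-out lower numbers stand for higher toxicity in this test and higher numbers for lower toxicity in this test), compound 1 gives 53800 nM.
Compound 2 `Cn1cc(SCc2nnc(SCc3cccc(Cl)c3Cl)n2-c2c(Cl)cccc2Cl)c2ccccc21` — in this assay compound 2 gives > 100000 nM, which is a limit of the assay and not a number.

Compound 2 therefore stands at the limit of this assay (the limit of > 100000 nM in this assay, at which 1 of the 2 values shown sits), and no number is known for it. Within the data shown here, the single measured step is an at least 1.8-fold higher number from compound 1 to compound 2 (0.26 log units; that floor lies within the scatter), in which one substituted phenyl replaced another on the saturated chain carbon bound to a sulfur without moving the result beyond the scatter. Compound 3 `Cn1cc(SCc2nnc(SCc3cccc(Cl)c3F)n2-c2c(Cl)cccc2Cl)c2ccccc21` differs from compound 2 by a smaller change: fluoro in place of chloro on an aromatic carbon. Among the measured compounds shown here, no measured pair separates chloro from fluoro at that position, so the data give no direction for this step; the only comparison available, the much larger change from compound 1 to compound 2, stayed within the scatter. The expectation is accordingly that compound 3 gives a result within the scatter of compound 2, most probably reported again as a limit, with the step of a number no higher from compound 2 to compound 3 (the limit leaves the size open) expected to be negligible. Compound 3 is estimated at 100000 nM, with an expected range from 50000 nM to 200000 nM.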

Compound 3, half-maximal cytotoxic concentration: > 100000 nM
Compound 3 gave a limit, no number; the forecaster's own chance of this, stated with the estimate: 70%; the middle value sits exactly at the limit.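

In this assay compound 3 gives > 100000 nM, which is a limit of the assay and not a number. With fluoro or with chloro on this aromatic carbon, ortho to a chloro group, the result is a limit and not a number, so the step between compound 2 and compound 3 cannot be read, because both sit at the same limit: the limit of > 100000 nM in this assay, at which 2 of the 3 values shown sit. Set against the 2-chloro-5-(trifluoromethyl)phenyl of compound 1, the 3-chloro-2-fluorophenyl group gives an at least 1.8-fold higher number from compound 1 to compound 3 (0.26 log units; that floor lies within the scatter), so this second replacement of that group also leaves only a floor, and one that does not pass beyond the scatter.

On these data alone, how far compound 2 and compound 3 lie from each other, and from compound 1, remains open, since only limits stand for the two of them. Also open, as far as these compounds go, is whether a bromo group or an amine on the same aromatic carbon would bring the result back to a readable number in this assay.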